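The compounds below may be only part of what the source reports. "The series", "measured", "known", "first", "only" and "open" are said of these compounds alone.

Measured in a functional assay on HL-60 cells (Homo sapiens) for cytotoxicity, read by MTT assay; a lower number here means a stronger inhibitor, a higher number a weaker inhibitor:
- compound 1 `COc1ccc(/C=N/NC(=O)c2cn(C3CC3)c3cc(N4CCNCC4)c(F)cc3c2=O)cc1O`: 25000 nM
- compound 2 `O=C(N/N=C/c1ccc([N+](=O)[O-])cc1)c1cn(C2CC2)c2cc(N3CCNCC3)c(F)cc2c1=O`: 25000 nM
- compound 3 `COc1cc(/C=N/NC(=O)c2cn(C3CC3)c3cc(N4CCNCC4)c(F)cc3c2=O)cc(OC)c1OC`: 25000 nM

Compound 3, at 25000 nM, stands level with compound 1 and compound 2 in this assay. Compound 4 `COc1ccc(/C=N/NC(=O)c2cn(C3CC3)c3cc(N4CCNCC4)c(F)cc3c2=O)cc1` differs from it at one place: 4-methoxyphenyl in place of 3,4,5-trimethoxyphenyl on a carbon with a double bond to nitrogen, with 4-methoxyphenyl in place of 3,4,5-trimethoxyphenyl on a carbon with a double bond to nitrogen. Three measured steps changed the group at this same place: no change at the digits printed from compound 1 to compound 3 (within the scatter), no change at the digits printed from compound 2 to compound 3 (within the scatter) and no change at the digits printed from compound 1 to compound 2 (within the scatter). All three lie within the scatter, so no shift beyond the scatter is expected here. The expected step is no change at the digits printed from compound 3 to compound 4 (within the scatter). Compound 4 is estimated at 25000 nM, with an expected range of 12000 nM to 50000 nM.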

Compound 4, half-maximal inhibitory concentration: 25000 nM
Estimate against measurement, compound 4: no gap at the digits printed, within the range that was stated.
By their numbers in this assay, from the lowest: compounds 1, 2, 3 and 4 (each within the scatter of the next).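

In this assay the step to the smaller 4-methoxyphenyl, with fewer heavy atoms and fewer hydrogen-bond acceptors than 3,4,5-trimethoxyphenyl, reads no change at the digits printed from compound 3 to compound 4 (within the scatter) and so trimming this group on the carbon with a double bond to nitrogen leaves the value flat. Single changes on the aromatic ring read alike: no change at the digits printed from compound 2 to compound 4 (within the scatter) for methoxy in place of nitro, and no change at the digits printed from compound 1 to compound 4 (within the scatter) for hydrogen in place of hydroxy. No evidence given here accounts for this flat result. On these data alone, whether an amine or a carboxylic acid on this phenyl would move the value stays open, as does any change to the shared core.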